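Replacing the pyridyl in compound 1 with chlorophenyl

The compounds below may be only part of what the source reports. "The series", "measured", "known", "first", "only" and "open" are said of these compounds alone.

Compound 1 `O=C(Cn1cc(-c2ccncc2)nn1)Nc1nccs1` gives 2 nM. Compound 2 `Cc1csc(NC(=O)Cn2cc(-c3ccncc3)nn2)n1` gives 100 nM. Compound 3 `Cc1cc(NC(=O)Cn2cc(-c3ccncc3)nn2)no1` gives 430 nM.

In a functional assay on BMDM cells (Mus musculus, strain C57BL/6) for inhibition, with a stated time of 2 days (on this read-out lower numbers stand for stronger inhibition and higher numbers for weaker inhibition), compound 1 stands lowest of the three, with a 50-fold higher number from compound 1 to compound 2 (1.70 log units; beyond the scatter) and a 220-fold higher number from compound 1 to compound 3 (2.33 log units; beyond the scatter). Compound 4 `O=C(Cn1cc(-c2ccc(Cl)cc2)nn1)Nc1nccs1` differs from compound 1 by 4-chlorophenyl in place of pyridin-4-yl on an aromatic carbon. Neither measured step touches this part of the shared core: both concern the amide-side ring, as in a 4.3-fold higher number from compound 2 to compound 3 (0.63 log units; beyond the scatter). Going by the values given here, no measured step therefore speaks to the change from compound 1 to compound 4, and any expectation rests on compound 1 alone. Compound 4 is expected to give 8 nM, within 1.5 nM to 60 nM; this estimate means a 4.0-fold higher number from compound 1 to compound 4 (0.60 log units; beyond the scatter), a step of uncertain direction.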

Compound 4, half-maximal inhibitory concentration: 1100 nM
Beside the measured number, compound 4's estimate is 140-fold (2.14 log units) below it; measured number above the stated range.
By their numbers in this assay, from the lowest: compound 1; then compound 2; then compound 3; then compound 4.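

In this assay, this position proves highly sensitive to the change, with a 550-fold higher number from compound 1 to compound 4 (2.74 log units; beyond the scatter), a larger step than either change on the amide side of compound 1. The exchange removes the ring nitrogen and the hydrogen-bond acceptor of pyridin-4-yl and brings in carbon and chlorine, and potency does not survive it. No measurement shown here explains this loss.

As far as these compounds go, it remains open whether the ring nitrogen or the chlorine decides the outcome, which plain phenyl or pyridin-3-yl could separate. Also open, from the compounds shown here alone, is whether an amine on the pyridine ring would be accepted.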